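Swapping a dimethylphenyl amide for a pyrazole: tolerability outlook

This account rests on a few compounds, and the source may have more. Where it says the series, first, only, none or still open, it means among the compounds named here.

Compound 1 `CCc1ccccc1NC(=O)[C@@H]1CCCN1S(=O)(=O)c1cccc2cccnc12` was tested in an ADME assay on HEp-2 cells (Homo sapiens) for cytotoxicity; a higher number here means that more compound is tolerated, a lower number that less compound is tolerated. In this assay compound 1 reached only the limit of > 50000 nM, which is a boundary of the measurement rather than a number. Compound 2 `Cc1cccc(C)c1NC(=O)[C@@H]1CCCN1S(=O)(=O)c1cccc2cccnc12` differs from it by having 2,6-dimethylphenyl in place of 2-ethylphenyl on an amide-type nitrogen. In this assay compound 2 likewise stopped at the limit of > 50000 nM. The step that the two limits leave unreadable from compound 1 to compound 2 therefore cannot be read in size or direction. Compound 2 thus stands at the boundary shared by both values shown, as the limit of > 50000 nM in this assay, at which 2 of the 2 values shown sit, records.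

Compound 3 `Cc1cc(NC(=O)[C@@H]2CCCN2S(=O)(=O)c2cccc3cccnc23)n(C(C)(C)C)n1` is not yet measured. Its change from compound 2 is 3-methyl-1-(tert-butyl)-1H-pyrazol-5-yl in place of 2,6-dimethylphenyl on an amide-type nitrogen. For the measured compounds named here, the only measured step bears on it just by analogy of place, and that step was unreadable, so no direction can be drawn from it. The expectation for compound 3 is therefore a step that the limit leaves unreadable from compound 2 to compound 3 that stays within the usual scatter. Compound 3 is expected to give about 70000 nM in this assay, within a range from 30000 nM to 200000 nM, most likely again reported only as a limit.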

Compound 3, half-maximal cytotoxic concentration: > 50000 nM
Compound 3 ended at the assay's limit; the forecaster's own chance of this, stated with the estimate: 80%; the middle value lies beyond the limit too.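

Compound 3 also ended at a limit in this assay, so the steps linking compound 1, compound 2 and compound 3 cannot be read in size or direction, and all three share one boundary: the limit of > 50000 nM in this assay, at which 3 of the 3 values shown sit.

The compounds shown leave open how much of each compound the cells would tolerate past that limit, and whether the three groups on the amide-type nitrogen differ at all.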